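Amide-nitrogen substituents on the shared core of compound 2

The source may report more compounds than this note shows. Statements on the series, on what has been measured and on what is new or still open speak of the compounds shown alone.

Measured so far in a functional assay on HepG2 cells (Homo sapiens), read by MTT assay, with a stated time of 48 h; on this read-out lower numbers stand for stronger inhibition and higher numbers for weaker inhibition:

compound 1 `CCOC(=O)CN(C)C(=O)c1ccc(C(CC)(CC)c2ccc(OCC(O)C(C)(C)C)c(C)c2)n1CC`: > 50000 nM
compound 2 `CCn1c(C(=O)NCCCN(C)C)ccc1C(CC)(CC)c1ccc(OCC(O)C(C)(C)C)c(C)c1`: 360 nM
compound 3 `C=CCN(C)C(=O)c1ccc(C(CC)(CC)c2ccc(OCC(O)C(C)(C)C)c(C)c2)n1CC`: > 50000 nM

Within the data shown here, compound 2 carries the only number in this set. The value of compound 1 is a limit of the assay, not a number. The value of compound 3 is likewise a limit; two of the three values sit at it (the limit of > 50000 nM in this assay, at which 2 of the 3 values shown sit). The step of an at least 130-fold lower number from compound 1 to compound 2 (2.14 log units; beyond the scatter) and the step of an at least 130-fold higher number from compound 2 to compound 3 (2.14 log units; beyond the scatter) are both large. The step that the two limits leave unreadable from compound 1 to compound 3 cannot be read because both ends are limits.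

Compound 4 `CC[C@@H](C)[C@H](NC(=O)c1ccc(C(CC)(CC)c2ccc(OCC(O)C(C)(C)C)c(C)c2)n1CC)C(=O)O` is not yet measured. It differs from compound 2 as follows: 1-carboxy-2-methylbutyl in place of 3-(dimethylamino)propyl on an amide-type nitrogen. Both measured changes on the carbonyl carbon that replaced the (3-(dimethylamino)propyl)amino group ended at the limit, and compound 4 again replaces that group, this time with (1-carboxy-2-methylbutyl)amino. A large upward step an 83-fold higher number from compound 2 to compound 4 (1.92 log units; beyond the scatter) is therefore expected, with a fair chance that only a limit is reported. Compound 4 is estimated at 30000 nM, with a range from 5000 nM to 100000 nM.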

Compound 4, half-maximal inhibitory concentration: 127 nM
Compound 4: middle estimate off by 240-fold (2.37 log units), on the high side, outside the stated range (below it).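

In this assay, a dimethylamino end is not needed for a measurable number on this amide-type nitrogen: with 1-carboxy-2-methylbutyl in place of 3-(dimethylamino)propyl, the result is a 2.8-fold lower number from compound 2 to compound 4 (0.45 log units; beyond the scatter). The same change of group on the carbonyl carbon also separates the new compound from the two other amides, with an at least 390-fold lower number from compound 3 to compound 4 (2.59 log units; beyond the scatter) and with an at least 390-fold lower number from compound 1 to compound 4 (2.59 log units; beyond the scatter). Those two steps start from limits of the assay, not numbers, held by compound 1 and compound 3: the limit of > 50000 nM in this assay, at which 2 of the 4 values shown sit.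

Compound 2 and compound 4 both keep the amide hydrogen, while compound 1 and compound 3 carry a methyl on that nitrogen, but these groups also differ in the rest of the substituent, so the amide hydrogen cannot be separated from the other changes. On these data alone, it also remains open whether the number of compound 4 follows the carboxylic acid, the 2-methylbutyl chain or the two defined stereocentres, and an ethyl ester of compound 4, its opposite stereoisomers or a version with a methyl on the amide nitrogen would each test one of these alone.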